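The source may hold more compounds than are shown below. What is called first, only, known or untested is meant among the compounds shown, and "the series" means these compounds.

Compound 1 `COc1ccc(/C=C/C(=O)NCCCC(C)Nc2cc(OC)cc3cccnc23)cc1` gives in an ADME assay on L6 cells (Rattus norvegicus) for cytotoxicity, read by resazurin assay, with a stated time of 70 h (a higher number here means a weaker inhibitor, a lower number a stronger inhibitor), only a limit, > 240000 nM.
Compound 2 `COc1cc(NC(C)CCCNC(=O)/C=C/c2ccccc2F)c2ncccc2c1` gives in this assay 3500 nM.

Compound 1 therefore stands at the limit of > 240000 nM in this assay, at which 1 of the 2 values shown sits, and has no number of its own. Compound 3 `COc1cc(NC(C)CCCNC(=O)/C=C/c2cccc(C(F)(F)F)c2)c2ncccc2c1` differs from it by 3-(trifluoromethyl)phenyl in place of 4-methoxyphenyl on a double-bonded chain carbon bound to a double-bonded chain carbon. For the measured compounds named here, the single measured step at that same place, an at least 68-fold lower number from compound 1 to compound 2 (1.83 log units; beyond the scatter), shows that exchanging the 4-methoxyphenyl can move the number far down. A lowering beyond the scatter is expected in this assay, though its size is uncertain, so the step is estimated at an at least 20-fold lower number from compound 1 to compound 3 (1.30 log units; beyond the scatter). Compound 3 is estimated at 12000 nM, with a range from 2000 nM to 120000 nM.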

Compound 3, half-maximal inhibitory concentration: 16200 nM
Compound 3: the middle estimate sits 1.4-fold (0.13 log units) below what was measured, within the range that was stated.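

A second replacement of the 4-methoxyphenyl, this time by 3-(trifluoromethyl)phenyl, also gives an at least 14-fold lower number from compound 1 to compound 3 (1.17 log units; beyond the scatter) in this assay, so the fall is not confined to the 2-fluorophenyl. The two replacements do not come out alike, with a 4.6-fold higher number from compound 2 to compound 3 (0.67 log units; beyond the scatter), so the entering group affects how far the number drops. The full size of the fall from compound 1 remains unknown, since that compound has only a limit: the limit of > 240000 nM in this assay, at which 1 of the 3 values shown sits.

Open, on these data alone, is how a phenyl carrying an amine or a carboxylic acid would behave at this place. Also open, as far as these compounds go, is whether the gap between the two replacements follows from the substituent itself or from where it sits on the ring.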